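The source may hold more compounds than are shown below. What is called first, only, known or untested is meant among the compounds shown, and "the series" means these compounds.

The three measured compounds are:

compound 1 `NC(=O)N1CCN(C(=S)SCc2cn(Cc3ccccc3F)nn2)CC1` — in a functional assay on EC9706 cells (Homo sapiens) for cytotoxicity, read by MTT assay, with a stated time of 72 h (on this read-out higher numbers stand for weaker inhibition and lower numbers for stronger inhibition), compound 1 gives 43100 nM
compound 2 `CCNC(=O)N1CCN(C(=S)SCc2cn(Cc3ccccc3F)nn2)CC1` — compound 2 gives 23700 nM
compound 3 `O=C(NC1CCCCC1)N1CCN(C(=S)SCc2cn(Cc3ccccc3F)nn2)CC1` — compound 3 gives 84900 nM

Compound 1 stands second highest of these three numbers. Its nearest neighbour is compound 2, with a 1.8-fold lower number from compound 1 to compound 2 (0.26 log units; within the scatter); its furthest is compound 3, with a 2.0-fold higher number from compound 1 to compound 3 (0.29 log units; within the scatter). For the measured compounds named here, only the step between the other two goes beyond the scatter: a 3.6-fold higher number from compound 2 to compound 3 (0.55 log units; beyond the scatter). All three of these steps change the group on the amide-type nitrogen and leave the rest of the shared core untouched.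

Compound 4 `Cc1ccc(Cn2cc(CSC(=S)N3CCN(C(N)=O)CC3)nn2)cc1` arises from compound 1 by a different kind of change: 4-methylphenyl in place of 2-fluorophenyl on a saturated chain carbon bound to an aromatic nitrogen. Going by the values given here, no measured step touches this part of the molecule, so there is nothing here to say how such a change moves the number in this assay. With no evidence either way, the expectation for compound 4 is a step of no meaningful size, a 1.0-fold higher number from compound 1 to compound 4 (0.02 log units; within the scatter), with a wide allowance. The estimate for compound 4 is therefore 45000 nM, expected to fall between 15000 nM and 135000 nM.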

Compound 4, half-maximal inhibitory concentration: > 128000 nM
Compound 4: only a limit was reported (the forecaster's own chance of this, stated with the estimate: 15%); at least 2.8-fold (0.45 log units) between middle value and limit.
By their numbers in this assay, from the lowest: compounds 2, 1 and 3 (each within the scatter of the next, the first and the last beyond it). At a limit, above all of these: compound 4.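

The earlier compounds shown here changed only the group on the amide-type nitrogen, so compound 4 gives the first view of a different part of the molecule. Placing 4-methylphenyl in place of 2-fluorophenyl on a saturated chain carbon bound to an aromatic nitrogen gives an at least 2.9-fold higher number from compound 1 to compound 4 (0.47 log units; beyond the scatter), which means weaker inhibition and shows that this position can affect the result in this assay. Compound 4 reached only a limit, so the full size of the step remains unknown: the limit of > 128000 nM in this assay, at which 1 of the 4 values shown sits.

The change removes the fluorine and adds a methyl in one move, so the compounds shown cannot separate the contribution of either one. As far as these compounds go, it also remains open how plain benzyl, 4-fluorobenzyl or a benzyl group carrying an amine or a carboxylic acid would behave here.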